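Aryl replacement at the ring nitrogen of the shared core

The compounds below may be only part of what the source reports. "The series", "measured", "known", "first", "only" and "open" are said of these compounds alone.

Two compounds of the series carry a number in a functional assay on Bel-7402 cells (Homo sapiens) for inhibition, read by sulforhodamine B assay, with a stated time of 72 h, tested at 10 uM; on this read-out higher numbers stand for more inhibition at the one concentration tested (going by the name of the read-out) and lower numbers for less inhibition. Compound 1 `C[C@H](Nc1ncnc2[nH]cnc12)c1nn(-c2ccc(C#N)cc2)c2cc(F)ccc12` gives 0%. Within the data shown here, compound 2 `C[C@H](Nc1ncnc2[nH]cnc12)c1nn(-c2cccc(S(C)(=O)=O)c2)c2cc(F)ccc12` gives -16%, the lowest of the two numbers; the only step within the measured pairs is a number 16 percentage points lower from compound 1 to compound 2 (beyond the scatter), which puts compound 2 beyond the scatter below compound 1.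

Compound 3 `C[C@H](Nc1ncnc2[nH]cnc12)c1nn(-c2cc(F)cc(F)c2)c2cc(F)ccc12` is not yet measured in this assay. Its change from compound 2 is 3,5-difluorophenyl in place of 3-(methylsulfonyl)phenyl on an aromatic nitrogen. Among the measured compounds shown here, no measured step concerns a difluorophenyl at this place; the single step from compound 1 to compound 2 exchanged one aryl group for another at the same aromatic nitrogen and moved the read-out by a modest amount, with neither compound showing inhibition at the concentration tested. A further aryl exchange at this position is therefore expected to leave the number near the range already seen, with no step beyond the scatter: the expected step is a number 11 percentage points higher from compound 2 to compound 3 (beyond the scatter). For compound 3 the estimate in this assay is -5%, with a range from -25% to 18%.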

Compound 3, a percentage reported as inhibition, at one concentration (the size of the read-out at that concentration, not a potency): -8%
Compound 3: the middle estimate sits 3 percentage points above what was measured; the range from low to high includes it.
By their numbers in this assay, from the lowest: compounds 2, 3 and 1 (each within the scatter of the next, the first and the last beyond it).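

Exchanging 3-(methylsulfonyl)phenyl for 3,5-difluorophenyl on the aromatic nitrogen gives a number 8 percentage points higher from compound 2 to compound 3 (within the scatter) in this assay, so the change from a group with 2 hydrogen-bond acceptors to one with none does not separate these two compounds on this read-out. Set against the 4-cyanophenyl group, the same 3,5-difluorophenyl group gives a number 8 percentage points lower from compound 1 to compound 3 (within the scatter) in this assay, which places compound 3 within the scatter of both earlier compounds and shows that the gap between them is not extended by a third aryl pattern, with no inhibition yet seen for any of these aryl groups at this position. Nothing available explains why these aryl exchanges make so little difference here.

Open, on these data alone, is whether an aminomethyl group or a carboxylic acid on the phenyl ring, or a longer alkyl chain in place of the ring on this nitrogen, would give real inhibition in this assay. Also open, as far as these compounds go, is whether changes elsewhere on the shared core would shift the read-out, and whether any aryl group at this position would then begin to matter.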